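A few compounds are considered here, and "the series" means these few. Any claim that something is new, unique, unknown or untested is made for them only; others in the source may bear on it.

Measured compounds:
- Compound 1 `CCCCCCn1ccc2cc(/C(C)=C/C(=O)Nc3ccccc3OCCCC(=O)O)ccc21`: 77 nM
- Compound 2 `CCC(C)n1ccc2cc(/C(C)=C/C(=O)Nc3ccccc3OCCCC(=O)O)ccc21`: 67 nM

Both compounds share one core and differ only in the group on the aromatic nitrogen. In an assay on Prostate gland for inhibition of steroid 5-alpha-reductase (Rattus norvegicus) (on this read-out lower numbers stand for stronger inhibition and higher numbers for weaker inhibition), compound 1 gives 77 nM, and compound 2 gives 67 nM. The step between them, a 1.1-fold lower number from compound 1 to compound 2 (0.06 log units; within the scatter), lies within the scatter, so the two values cannot be told apart. On the numbers shown, compound 2 has the lowest value of the two, with compound 1 its nearest neighbour.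

Compound 3 `CCCCCC(CCCCC)n1ccc2cc(/C(C)=C/C(=O)Nc3ccccc3OCCCC(=O)O)ccc21` is not yet measured. It differs from compound 2 in one place: 1-pentylhexyl in place of sec-butyl on an aromatic nitrogen. For the measured compounds named here, the only measured step that bears on this change is the swap of groups at the same aromatic nitrogen, a 1.1-fold lower number from compound 1 to compound 2 (0.06 log units; within the scatter), which was within the scatter. That single step gives no sign that the size of the group on the aromatic nitrogen moves the number in either direction, so in this assay no step beyond the scatter is expected for compound 3, though a single step is a thin basis for a group of this kind. The expected step is a 1.0-fold higher number from compound 2 to compound 3 (0.02 log units; within the scatter). For compound 3 the estimated value in this assay is 70 nM, with a range from 25 nM to 200 nM.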

Compound 3, half-maximal inhibitory concentration: 25 nM
For compound 3 the middle estimate is 2.8-fold (0.45 log units) above the measured one; measured number inside the range.
By their numbers in this assay, from the lowest: compound 3; then compounds 2 and 1 (each within the scatter of the next).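

In this assay, for the compounds shown here, the group on the aromatic nitrogen can clearly move the number: 1-pentylhexyl in place of sec-butyl gives a 2.7-fold lower number from compound 2 to compound 3 (0.43 log units; beyond the scatter), the first step at this position that lies beyond the scatter, though it is modest. Compared with hexyl, pentyl in place of hydrogen on the saturated chain carbon bound to the aromatic nitrogen gives a 3.1-fold lower number from compound 1 to compound 3 (0.49 log units; beyond the scatter), so compound 3 stands apart from both earlier compounds, and the change from sec-butyl adds only carbon, going from 4 to 11 heavy atoms with no ring, hydrogen-bond donor, hydrogen-bond acceptor or charge on either side. Nothing measured here accounts for this lower number.

With only these three groups, the size of the group and the two long arms on one carbon cannot be separated, so a shorter branched group such as 1-propylbutyl would be informative. As far as these compounds go, it also remains open whether a ring such as cyclohexyl, or an amine or ether placed within the chain, would keep the number as low as that of compound 3.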